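A few compounds are considered here, and "the series" means these few. Any claim that something is new, unique, unknown or untested is made for them only; others in the source may bear on it.

Compound 1 `Cc1ccc(C(CCN(C)C)NC(=O)C#Cc2ccccc2)cc1` reaches 131% in a functional assay on NIH3T3 cells for agonist activity at Urotensin-2 receptor (Homo sapiens), with a stated time of 5 days; a higher number here means a larger maximal response, a lower number a smaller maximal response. Compound 2 `CN(C)CCC(NC(=O)C#Cc1ccccc1)c1ccc(Cl)cc1`, in this assay, reaches 124%. For the measured compounds named here, the only change between the two is chloro in place of methyl on an aromatic carbon, and it made the step of a number 7 percentage points lower from compound 1 to compound 2 (within the scatter). Going by the values given here, compound 3 `Cc1ccc(C(CCN(C)C)NC(=O)/C=C/c2ccc(C(F)(F)F)cc2)cc1` gives 96% in this assay; how its core differs from the core of compound 1 is not broken down here, and the two values show only that compound 3 stands lower than both compound 1 and compound 2 by more than the usual scatter.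

Compound 4 `CN(C)CCC(NC(=O)/C=C/c1ccc(C(F)(F)F)cc1)c1ccc(Cl)cc1` has not yet been measured. It differs from compound 3 by chloro in place of methyl on an aromatic carbon, the same change that was made from compound 1 to compound 2, in the same place. Since the earlier step of a number 7 percentage points lower from compound 1 to compound 2 (within the scatter) stayed within the scatter, the expected step from compound 3 to compound 4 is likewise small, a number 7 percentage points lower from compound 3 to compound 4 (within the scatter). Compound 4 is therefore estimated to reach 89% in this assay, with a plausible range from 70% to 110%.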

Compound 4, largest response reached (reported as efficacy), in percent of the reference or control that the assay uses: 133%
The estimate for compound 4 lay 44 percentage points below the measured number; the measured number lies above the stated range.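

In this assay, the swap of 4-methylphenyl to 4-chlorophenyl gave a number 37 percentage points higher from compound 3 to compound 4 (beyond the scatter). The small step seen on the core of compound 1 therefore did not carry over to the other core, and the two steps part by more than the scatter: the same change on two cores in this assay, a number 7 percentage points lower (within the scatter) from compound 1 to compound 2 and a number 37 percentage points higher (beyond the scatter) from compound 3 to compound 4, 44 percentage points apart, beyond the scatter of two such steps. This shows that, in this series, the effect of the change on the maximal response depends on the core it is made on, but it does not show which feature of the cores is responsible, and two pairs give no rule for what the same change would do on a third core.

The compounds shown leave open how a fluoro, bromo or methoxy group would compare with methyl and chloro in the same place on each core. They also leave open whether the same swap would give a small or a large step on a core carrying a nitrile in place of the trifluoromethyl group.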